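The compounds below may be only part of what the source reports. "The series", "measured", "known", "first", "only" and "open" are said of these compounds alone.

Measured compounds:
- compound 1, `Cc1ccc(S(=O)(=O)c2cc3cnc(Nc4cnc5c(c4)CC(=O)N5)nc3n(C)c2=O)cc1`: 15000 nM
- compound 2, `Cn1c(=O)c(S(=O)(=O)c2ccc(Cl)cc2)cc2cnc(Nc3cnc4[nH]ccc4c3)nc21`: 5000 nM

Both compounds share a common core and were tested in a functional assay on DU-145 cells (Homo sapiens) for inhibition, read by trypan blue exclusion, with a stated time of 72 h; on this read-out lower numbers stand for stronger inhibition and higher numbers for weaker inhibition. Compound 1 gives 15000 nM in this assay, which is the higher of the two numbers, and so the weaker inhibition. Compound 2 gives 5000 nM, a step down from compound 1 that lies beyond the usual scatter. These two differ in more than one place, so their gap cannot be tied to a single change.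

Compound 3, `Cc1ccc(S(=O)(=O)c2cc3cnc(Nc4cccc5[nH]ccc45)nc3n(C)c2=O)cc1`, has not yet been measured. It differs from compound 1 in one place: a group of 9 heavy atoms (8 carbon, 1 nitrogen; one five-membered aromatic ring with 1 hetero atom, one six-membered aromatic ring of carbon only) in place of a group of 10 heavy atoms (7 carbon, 2 nitrogen, 1 oxygen; one five-membered non-aromatic ring with 1 hetero atom, one six-membered aromatic ring with 1 hetero atom), on a nitrogen on an aromatic ring. The group that enters is an all-aromatic, two-ring piece with one hydrogen-bond donor and no acceptor, where the group that leaves had a non-aromatic five-membered ring and an extra acceptor. For the measured compounds named here, no measured pair isolates this change, so the expected direction rests only on compound 2, whose amine substituent is closer in kind to that of compound 3. Compound 2 gives 5000 nM, which sits below the number of compound 1.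

The step from compound 1 to compound 3 is estimated as a 2.5-fold lower number from compound 1 to compound 3 (0.40 log units; beyond the scatter), toward a somewhat lower number. Compound 3 is therefore expected to give about 6000 nM, within a range from 1500 nM to 25000 nM.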

Compound 3, half-maximal inhibitory concentration: 10000 nM
Estimate against measurement, compound 3: 1.7-fold (0.22 log units) below; the range from low to high includes it.
By their numbers in this assay, from the lowest: compounds 2, 3 and 1 (each within the scatter of the next, the first and the last beyond it).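

For the compounds shown here, replacing the two-ring group of compound 1 with 1H-indol-4-yl, on a nitrogen on an aromatic ring, gives a 1.5-fold lower number from compound 1 to compound 3 (0.18 log units; within the scatter) in this assay, and this is the first step here that isolates a single change. This read-out therefore does not separate the two groups, although one has a five-membered non-aromatic ring, 10 heavy atoms and 2 hydrogen-bond acceptors, while the other is fully aromatic, with 9 heavy atoms and 0 hydrogen-bond acceptors; both carry 1 hydrogen-bond donor. Nothing further is available to explain why these two different groups read alike in these cells.

The compounds shown leave open what this position would give with a group that has no hydrogen-bond donor, such as a plain phenyl, or with a saturated ring such as morpholine or piperazine, and whether any of these would move the number beyond the scatter. From the compounds shown here alone, it also remains open whether this swap would read the same way with the 4-chlorophenyl group of compound 2 on the sulfonyl in place of the 4-methylphenyl group.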